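Thiourea-amide series: fluoro for methyl on the anilino ring

This account rests on a few compounds, and the source may have more. Where it says the series, first, only, none or still open, it means among the compounds named here.

Measured so far in a functional assay on NCI-H460 cells (Homo sapiens) for inhibition, read by CCK-8 assay, with a stated time of 48 h; on this read-out lower numbers stand for stronger inhibition and higher numbers for weaker inhibition:
compound 1 `Cc1ccc(NC(=S)NC(=O)c2cn(-c3ccccc3)nc2-c2ccc(Cl)cc2)cc1` 3120 nM
compound 2 `Cc1ccc(NC(=S)NC(=O)c2cn(-c3ccccc3)nc2-c2ccc(C)cc2)cc1` 3760 nM

Compound 1 gives the lower of the two numbers in this assay, with compound 2 a 1.2-fold higher number from compound 1 to compound 2 (0.08 log units; within the scatter). Within the data shown here, the only measured step thus sits on the aryl group attached to the shared core and stays within the scatter.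

Compound 3 `O=C(NC(=S)Nc1ccc(F)cc1)c1cn(-c2ccccc2)nc1-c1ccc(Cl)cc1` is the next candidate. Relative to compound 1 the change is fluoro in place of methyl on an aromatic carbon. No measured step touches this ring, so nothing shown bears directly on the change; the one step that exists, from compound 1 to compound 2, lies on another ring and is within the scatter. With a single small substituent exchanged for another, the working expectation for compound 3 in this assay is no shift beyond the scatter, a 1.1-fold higher number from compound 1 to compound 3 (0.02 log units; within the scatter). Compound 3 is therefore estimated at 3300 nM, with a range from 1500 nM to 7500 nM.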

Compound 3, half-maximal inhibitory concentration: 3640 nM
Estimate against measurement, compound 3: 1.1-fold (0.04 log units) below; low and high end bracket the measured number.
By their numbers in this assay, from the lowest: compounds 1, 3 and 2 (each within the scatter of the next).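

In the working series, the ring carrying the (4-methylphenyl)amino group now has a measured step of its own in this assay: fluoro in place of methyl, para to a large group, gives a result within the scatter (a 1.2-fold higher number from compound 1 to compound 3 (0.07 log units; within the scatter)). This position thus joins the aryl group changed in the earlier step (a 1.2-fold higher number from compound 1 to compound 2 (0.08 log units; within the scatter)), and neither exchange of one small substituent for another separates the compounds. The data shown offer nothing that could explain this flat result.

Open, going by these compounds, is whether an amine, a carboxylic acid or a longer chain such as butyl in this same place would move the number beyond the scatter. Also open, on these data alone, is whether a methoxy or trifluoromethyl group would do so on either ring.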